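The compounds below may be only part of what the source reports. "The series", "measured", "known", "first", "only" and "open" are said of these compounds alone.

Working notes on the series.

Three compounds have numbers in an assay on isolated protein for inhibition of Rho-associated protein kinase 2 (Homo sapiens), read by a luciferase reporter; on this read-out lower numbers stand for stronger inhibition and higher numbers for weaker inhibition. Compound 1 `O=C(Nc1cc2cc[nH]c(=O)c2cc1Cl)C1CNCC1c1ccccn1` gives 14 nM. Compound 2 `CC(C)(C)c1cccc(C2CNCC2C(=O)Nc2cc3cc[nH]c(=O)c3cc2Cl)c1` gives 11 nM. Compound 3 `O=C(Nc1cc2cc[nH]c(=O)c2cc1Cl)[C@@H]1CCCNC1` gives 47 nM. Compound 2 holds the lowest of the three numbers; its nearest neighbour is compound 1, and the step of a 1.3-fold lower number from compound 1 to compound 2 (0.10 log units; within the scatter) is within the scatter, so the two cannot be ranked against each other. Compound 3 stands furthest from compound 2, at a gap beyond the scatter.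

Compound 4 `O=C(Nc1cc2cc[nH]c(=O)c2cc1Cl)C1CNCC1c1ccc(Cl)cc1Cl` has not been measured. Its change from compound 2 is 2,4-dichlorophenyl in place of 3-(tert-butyl)phenyl on a saturated ring carbon. Among the measured compounds shown here, one measured step bears on it: the exchange of one aromatic group for another on the same saturated ring carbon, from compound 1 to compound 2, moved this assay by a 1.3-fold lower number from compound 1 to compound 2 (0.10 log units; within the scatter), which is within the scatter. On that basis an aryl swap at this position is expected to shift the number little, in no clear direction, and the step of a 1.4-fold higher number from compound 2 to compound 4 (0.13 log units; within the scatter) is therefore estimated to stay within the scatter. Compound 4 is expected to give about 15 nM in this assay, with a range from 6 nM to 40 nM.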

Compound 4, half-maximal inhibitory concentration: 8 nM
Compound 4: middle estimate off by 1.9-fold (0.27 log units), on the high side; low and high end bracket the measured number.
By their numbers in this assay, from the lowest: compounds 4, 2 and 1 (each within the scatter of the next); then compound 3.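

With 2,4-dichlorophenyl on the saturated ring carbon, this assay shows a 1.4-fold lower number from compound 2 to compound 4 (0.14 log units; within the scatter) and a 1.8-fold lower number from compound 1 to compound 4 (0.24 log units; within the scatter) for the two exchanges of one aromatic group for another. Three different aromatic groups, pyridin-2-yl, 3-(tert-butyl)phenyl and 2,4-dichlorophenyl, now stand at this position with no step beyond the scatter, so the earlier single step is no longer an isolated case. Nothing measured beyond these numbers bears on why the three compounds read alike.

The compounds shown leave open whether a group without an aromatic ring at this carbon, such as cyclohexyl or a short aminoalkyl chain, would stay in the same range. As far as these compounds go, it is also open whether an aryl group carrying a carboxylic acid or an amine would do so.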